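The source may report more compounds than this note shows. Statements on the series, on what has been measured and on what is new or still open speak of the compounds shown alone.

In a functional assay on SH-SY5Y cells (Homo sapiens) for antiproliferative activity, read by MTT assay, with a stated time of 48 h (a higher number here means a weaker inhibitor of growth, a lower number a stronger inhibitor of growth), compound 3 `COc1ccc(N(C)c2ncnc3c2ncn3Cc2cc(OC)cc(OC)c2)cc1` gives > 100000 nM, which is a limit of the assay and not a number. Compound 1 `COc1ccc(Cn2cnc3c(N(C)c4ccc(OC)cc4)ncnc32)cc1` gives 27000 nM, and compound 2 `COc1ccc(N(C)c2ncnc3c2ncn3Cc2ccc(OC)c(OC)c2)cc1` gives 430 nM. Compound 4 `COc1ccc(N(C)c2ncnc3c2ncn3Cc2cc(OC)c(OC)c(OC)c2)cc1` differs from compound 3 in one place: methoxy in place of hydrogen on an aromatic carbon. This is methoxy in place of hydrogen on an aromatic carbon, ortho to two methoxy groups. The same kind of change produced a large step, a 63-fold lower number from compound 1 to compound 2 (1.80 log units; beyond the scatter). Moving the methoxy groups mattered as well, with a large step of an at least 230-fold higher number from compound 2 to compound 3 (2.36 log units; beyond the scatter) and an at least modest one an at least 3.7-fold higher number from compound 1 to compound 3 (0.56 log units; beyond the scatter). Compound 4 keeps every ring methoxy of compound 2 and carries one more, so a large step towards a lower number is expected in this assay. Going by the values given here, no compound yet tests that extra methoxy alongside the others, so the range stays wide. The expected change is an at least 33-fold lower number from compound 3 to compound 4 (1.52 log units; beyond the scatter). For compound 4 the estimated value is 3000 nM, with an expected range from 200 nM to 50000 nM.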

Compound 4, concentration for 50% growth inhibition: 260 nM
Compound 4: the middle estimate sits 12-fold (1.06 log units) above what was measured; the range from low to high includes it.
By their numbers in this assay, from the lowest: compounds 4 and 2 (each within the scatter of the next); then compound 1. At a limit, above all of these: compound 3.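

Starting from compound 3, whose value is a limit of the assay and not a number, a methoxy placed ortho to two methoxy groups and para to a large group gives an at least 380-fold lower number from compound 3 to compound 4 (2.58 log units; beyond the scatter) in this assay. Added to compound 2, a methoxy gives only a 1.7-fold lower number from compound 2 to compound 4 (0.22 log units; within the scatter), so the same kind of change is large from one ring pattern and stays within the scatter from another. The size of this change therefore differs with its surroundings, as the two large steps also show: the same change on two cores in this assay, a 63-fold lower number (1.80 log units; beyond the scatter) from compound 1 to compound 2 and an at least 380-fold lower number (2.58 log units; beyond the scatter) from compound 3 to compound 4, at least 6.1-fold (0.78 log units) apart, beyond the scatter of two such steps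

Going by these compounds, what a hydroxyl, a fluorine or an ethoxy would do at this place remains open. On these data alone, it also remains open whether the step from compound 3 needs an oxygen on that carbon at all, or whether any other group there would serve.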